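A few compounds are considered here, and "the series" means these few. Any claim that something is new, unique, unknown or untested is made for them only; others in the source may bear on it.

Measured compounds in this series:

compound 1, `NC(=O)c1c(NC(=O)c2ccccc2Cl)sc2c1CCN(C(=O)Nc1ccccc1Cl)C2`: in a functional assay on HeLa cells (Homo sapiens) for antiproliferative activity, with a stated time of 24 h (a higher number here means a weaker inhibitor, a lower number a stronger inhibitor), compound 1 gives 45400 nM.
compound 2, `Cc1ccc(C(=O)Nc2sc3c(c2C(N)=O)CCN(C(=O)Nc2ccccc2Cl)C3)cc1`: in this assay compound 2 gives 32900 nM.

Within the data shown here, compound 2 stands at the lower of the two numbers known so far, but its nearest neighbour is compound 1 and the two values lie within the scatter of each other, so no order between them can be claimed. Among the measured compounds shown here, the one measured step, a 1.4-fold lower number from compound 1 to compound 2 (0.14 log units; within the scatter), exchanges an aryl group on the carbonyl carbon of the amide and leaves the number essentially unchanged.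

Compound 3, `NC(=O)c1c(NC(=O)c2cccc([N+](=O)[O-])c2)sc2c1CCN(C(=O)Nc1ccccc1Cl)C2`, is the next entry. The change from compound 2 is 3-nitrophenyl in place of 4-methylphenyl on a carbonyl carbon. For the measured compounds named here, this is the same kind of exchange as the only measured step, a new aryl group on the same carbonyl carbon, and that step stayed within the scatter. Nothing measured covers a nitro group, so the expectation rests on a single precedent. On that basis the expected step for compound 3 is a 1.1-fold higher number from compound 2 to compound 3 (0.04 log units; within the scatter), no shift beyond the scatter. The estimate for compound 3 in this assay is 36000 nM, with a range from 12000 nM to 100000 nM.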

Compound 3, half-maximal inhibitory concentration: > 50000 nM
Compound 3 gave a limit, no number; the forecaster's own chance of this, stated with the estimate: 10%; at least 1.3-fold (0.14 log units) between middle value and limit.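

In this assay compound 3 gives > 50000 nM, which is a limit and not a number: the limit of > 50000 nM in this assay, at which 1 of the 3 values shown sits. Placing 3-nitrophenyl on this carbonyl carbon gives an at least 1.5-fold higher number from compound 2 to compound 3 (0.18 log units; that floor lies within the scatter), and the same group compared with the 2-chlorophenyl case gives an at least 1.1-fold higher number from compound 1 to compound 3 (0.04 log units; that floor lies within the scatter). Among these compounds, this is the first group at this position that returns no number, but both steps are floors within the scatter, so the data do not show that this change moves the value more than the exchange of 2-chlorophenyl for 4-methylphenyl did, and they set no upper bound on its size.

Going by these compounds, whether compound 3 truly separates from compound 1 and compound 2 stays open, and a reading below the limit for a close analogue would be needed to settle it. Also open, on these data alone, is how this carbonyl carbon tolerates groups of another kind, such as a phenyl ring carrying an amine or a carboxylic acid, or a longer alkyl chain in place of the aryl group.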